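From 2-bromophenyl to vinyl on the sulfur chain

The compounds below may be only part of what the source reports. "The series", "measured", "known", "first", "only" and "open" are said of these compounds alone.

Values measured in a functional assay on MCF7 cells (Homo sapiens) for inhibition, read by MTT assay, with a stated time of 72 h; on this read-out lower numbers stand for stronger inhibition and higher numbers for weaker inhibition:
Compound 1 (`Cc1cc(Nc2cc(-c3ccccc3)[nH]n2)n2nc(SCCc3ccccc3)nc2n1`) gives 2700 nM
Compound 2 (`Cc1cc(Nc2cc(-c3ccccc3)[nH]n2)n2nc(SCc3ccccc3Br)nc2n1`) gives 3020 nM

For the measured compounds named here, compound 2 stands level with compound 1, the only other measured compound, since their numbers lie within the scatter of each other. Compound 3 (`C=CCSc1nc2nc(C)cc(Nc3cc(-c4ccccc4)[nH]n3)n2n1`) differs from compound 2 as follows: vinyl in place of 2-bromophenyl on a saturated chain carbon bound to a sulfur. Going by the values given here, the one measured step at this place is small (a 1.1-fold higher number from compound 1 to compound 2 (0.05 log units; within the scatter)), but no measured compound lacks a ring there, so the evidence is thin. No step beyond the scatter is expected in this assay for this change. The expected step is a 1.3-fold higher number from compound 2 to compound 3 (0.12 log units; within the scatter) as an estimate. For compound 3 the estimated value is 4000 nM with an expected range of 1800 nM to 10000 nM in this estimate.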

Compound 3, half-maximal inhibitory concentration: > 50000 nM
Compound 3 gave a limit, no number (the forecaster's own chance of this, stated with the estimate: 10%); middle value at least 12-fold (1.09 log units) away from the limit.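

Compound 1 and compound 2 suggested that this place on the sulfur chain tolerates change, but the switch to vinyl brings an at least 16-fold higher number from compound 2 to compound 3 (1.21 log units; beyond the scatter) and an at least 18-fold higher number from compound 1 to compound 3 (1.26 log units; beyond the scatter). Compound 3 gives a limit, not a number: the limit of > 50000 nM in this assay, at which 1 of the 3 values shown sits. Among these three compounds, inhibition in the measured range goes with an aromatic ring on the chain, which compound 3 lacks.

This change removes the ring and shortens the group together, so the two effects stay unseparated. From the compounds shown here alone, whether a hexyl chain or a cyclohexyl ring would restore inhibition remains open.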